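A few compounds are considered here, and "the series" means these few. Any claim that something is new, unique, unknown or untested is made for them only; others in the source may bear on it.

Measured compounds:
- compound 1, `CCCCCCCCNC(=O)[C@@H](NC(=O)c1ccco1)[C@@H](C)O`: 64500 nM
- compound 2, `CCCCCCCCNC(=O)[C@@H](NC(=O)c1nccc2ccccc12)[C@@H](C)O`: 26900 nM

In a functional assay on A-431 cells (Homo sapiens) for cytotoxicity, read by MTT assay, with a stated time of 48 h (on this read-out higher numbers stand for weaker inhibition and lower numbers for stronger inhibition), compound 2 holds the lower of the two numbers, and compound 1 sits a step above it that lies beyond the scatter. Compound 3, `CCCCCCCCCCCCCCCCCCNC(=O)[C@@H](NC(=O)c1nccc2ccccc12)[C@@H](C)O`, is not yet measured; it differs from compound 2 by decyl in place of hydrogen on a saturated chain carbon, eight bonds along the chain from an amide-type nitrogen. Among the measured compounds shown here, no measured pair in this set shows what such a chain extension does. Without a comparable step, a moderate gain in this assay is expected rather than a loss, and the step of a 1.8-fold lower number from compound 2 to compound 3 (0.25 log units; within the scatter) is the estimated size. For compound 3 the expected value is 15000 nM, with a range from 4000 nM to 60000 nM.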

Compound 3, half-maximal inhibitory concentration: 44100 nM
For compound 3 the middle estimate is 2.9-fold (0.47 log units) below the measured one; low and high end bracket the measured number.
By their numbers in this assay, from the lowest: compounds 2, 3 and 1 (each within the scatter of the next, the first and the last beyond it).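

In this assay, decyl in place of hydrogen on a saturated chain carbon, eight bonds along the chain from an amide-type nitrogen, gives a 1.6-fold higher number from compound 2 to compound 3 (0.21 log units; within the scatter) and so does not separate the two compounds. At this position, the series therefore tolerates this chain extension without a change that can be read beyond the scatter. No available evidence bears on this result.

Open, from the compounds shown here alone, is how a chain ending in an amine or a carboxylic acid would read at this position. Also open, going by these compounds, is whether a dodecyl chain on the core of compound 1 would give the same picture.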